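A few compounds are considered here, and "the series" means these few. Any claim that something is new, unique, unknown or untested is made for them only; others in the source may bear on it.

Compound 1 `COc1cccc(/C=C2\CCCN=C2c2cccnc2)c1`: 1180 nM
Compound 2 `Cc1cc(O)cc(C)c1/C=C1\CCCN=C1c1cccnc1`: 670 nM
Compound 3 `FC(F)Oc1ccc(/C=C2\CCCN=C2c2cccnc2)cc1`: 1160 nM

In an assay on membranes from brain for displacement of a labelled ligand from Neuronal acetylcholine receptor; alpha4/beta2 (Rattus norvegicus), with a stated time of 3 h (on this read-out lower numbers stand for stronger inhibition and higher numbers for weaker inhibition), compound 3 gives 1160 nM. Its number sits between the other two, and both neighbours lie within the scatter of it: compound 1 gives 1180 nM, and compound 2 gives 670 nM. Compound 4 `Clc1ccc(/C=C2\CCCN=C2c2cccnc2)cc1` has not been measured. It differs from compound 3 by chloro in place of difluoromethoxy on an aromatic carbon. Going by the values given here, no pair of measured compounds isolates this position, so the data give no step to lean on. The three measured numbers all fall within the scatter of one another, so the expected step in this assay is small, a 1.3-fold lower number from compound 3 to compound 4 (0.11 log units; within the scatter), with neither direction favoured. Compound 4 is therefore estimated at about 900 nM, within a range of 350 nM to 2500 nM.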

Compound 4, inhibition constant: 970 nM
Estimate against measurement, compound 4: 1.1-fold (0.03 log units) below; the measured number falls inside the stated range.
By their numbers in this assay, from the lowest: compounds 2, 4, 3 and 1 (each within the scatter of the next).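

In this assay, going by these compounds alone, chloro in place of difluoromethoxy, on an aromatic carbon para to a large group, gives a 1.2-fold lower number from compound 3 to compound 4 (0.08 log units; within the scatter) as the first step that isolates this position. Exchanging a group of 4 heavy atoms and 1 hydrogen-bond acceptor for a single chlorine with no acceptor therefore leaves the number within the scatter. Nothing measured here bears on a cause for this result.

The compounds shown leave open how an amine or a carboxylic acid at this position would read in this assay, since both chloro and difluoromethoxy carry neither group.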